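The compounds below may be only part of what the source reports. "The series", "measured", "known", "first", "only" and "open" are said of these compounds alone.

Measured compounds in an assay on cells for displacement of a labelled ligand from 5-hydroxytryptamine receptor 6 (Homo sapiens), read by scintillation counting, with a stated time of 1.5 h; a higher number here means a weaker inhibitor, a lower number a stronger inhibitor:
Compound 1, `Fc1ccc(-c2noc3c2CCNCC3)cc1`: > 10000 nM, a limit of this assay.
Compound 2, `Cc1ccc(-c2noc3c2CCNCC3)cc1`: 492 nM.

Compound 2 holds the only number shown in this assay; the other value is a limit, namely (the limit of > 10000 nM in this assay, at which 1 of the 2 values shown sits). Going by the values given here, the single measured step, an at least 20-fold lower number from compound 1 to compound 2 (1.30 log units; beyond the scatter), shows methyl in place of fluoro on the aromatic carbon being strongly favoured.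

Compound 3, `Clc1ccc(-c2noc3c2CCNCC3)cc1`, differs from compound 2 by chloro in place of methyl on an aromatic carbon. The measured step concerns a different exchange at the same place, so it bears only indirectly. For compound 3 a step of about a 1.4-fold lower number from compound 2 to compound 3 (0.15 log units; within the scatter) is expected, within the scatter. The estimate for compound 3 is 350 nM, range 90 nM to 1500 nM.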

Compound 3, inhibition constant: 360 nM
The estimate for compound 3 lay 1.0-fold (0.01 log units) below the measured number; low and high end bracket the measured number.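

At the aromatic carbon para to a large group, chloro and methyl cannot be told apart in this assay: a 1.4-fold lower number from compound 2 to compound 3 (0.14 log units; within the scatter). Fluoro now stands apart from both of these groups, not from methyl alone, with an at least 27-fold lower number from compound 1 to compound 3 (1.44 log units; beyond the scatter). Compound 1 stands at a limit in this assay: the limit of > 10000 nM in this assay, at which 1 of the 3 values shown sits.

From the compounds shown here alone, what a methoxy, an amine or a carboxylic acid would give at this carbon stays open, as does any change to the shared core. The compounds shown also leave open why fluoro parts from chloro and methyl.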